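Swapping a butyl chain for a cyanophenyl ring on the diester core

The compounds below may be only part of what the source reports. "The series", "measured", "known", "first", "only" and "open" are said of these compounds alone.

Three diesters sharing one core have been measured in an ADME assay on a cell-free system (plasma, Homo sapiens) for metabolic stability, with Plasma (Rattus norvegicus) as the target, read by HPLC, at pH 7.4; a lower number here means that the compound disappears faster, a higher number that the compound lasts longer. Compound 2 `CCCCC(=O)O[C@@H]1CO[C@H]2[C@@H]1OC[C@@H]2OC(=O)c1ccccc1OC(C)=O` gives 0.0198 h, the lowest of the three. Compound 1 `CC(=O)Oc1ccccc1C(=O)O[C@H]1CO[C@H]2[C@@H]1OC[C@H]2OC(=O)c1snnc1C` gives 0.0642 h, and compound 3 `CC(=O)Oc1ccccc1C(=O)O[C@H]1CO[C@H]2[C@@H]1OC[C@H]2OC(=O)c1ccc([N+](=O)[O-])cc1` gives 0.0462 h. The step of a 2.3-fold higher number from compound 2 to compound 3 (0.37 log units; beyond the scatter) and the step of a 3.2-fold lower number from compound 1 to compound 2 (0.51 log units; beyond the scatter) both show that replacing the butyl on the carbonyl carbon with a ring raises the number modestly. Compound 4 `CC(=O)Oc1ccccc1C(=O)O[C@H]1CO[C@H]2[C@@H]1OC[C@H]2OC(=O)c1ccc(C#N)cc1` carries a related change: 4-cyanophenyl in place of butyl on a carbonyl carbon. Because of the step of a 2.3-fold higher number from compound 2 to compound 3 (0.37 log units; beyond the scatter), a similar modest rise is expected for compound 4, estimated at a 2.3-fold higher number from compound 2 to compound 4 (0.36 log units; beyond the scatter). Compound 4 is therefore expected to give about 0.045 h in this assay, within a range from 0.02 h to 0.1 h.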

Compound 4, half-life: 0.0888 h
Estimate against measurement, compound 4: 2.0-fold (0.30 log units) below, and the stated range covers the measured number.
By their numbers in this assay, from the lowest: compound 2; then compounds 3, 1 and 4 (each within the scatter of the next).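

In this assay, 4-cyanophenyl in place of butyl on this carbonyl carbon gives a 4.5-fold higher number from compound 2 to compound 4 (0.65 log units; beyond the scatter), so a third ring also lasts longer than the butyl chain, with no listed compound going against this. Among the rings, cyano in place of nitro gives a 1.9-fold higher number from compound 3 to compound 4 (0.28 log units; within the scatter) and 4-cyanophenyl in place of 4-methyl-1,2,3-thiadiazol-5-yl gives a 1.4-fold higher number from compound 1 to compound 4 (0.14 log units; within the scatter), so these three ring groups cannot be told apart here. Nothing available explains the difference between ring and chain. From the compounds shown here alone, whether an amine or a longer chain at this position would last as long remains open.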